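A few compounds are considered here, and "the series" means these few. Any claim that something is new, unique, unknown or untested is made for them only; others in the source may bear on it.

Measured compounds in a functional assay on isolated protein for inhibition of Glucose-dependent insulinotropic receptor (Rattus norvegicus), read by HTRF and cAMP accumulation; a lower number here means a smaller maximal response, a higher number a larger maximal response:
- Compound 1 `Cc1nc(S(C)(=O)=O)ccc1Oc1ncnc(OC2CCN(C(=O)OC(C)(C)C(F)(F)F)CC2)c1F` gives 79%.
- Compound 2 `Cc1nc(S(C)(=O)=O)ccc1Oc1ncnc(OC2CCN(C(=O)SC(C)(C)C)CC2)c1F` gives 76%.
- Compound 3 `Cc1nc(S(C)(=O)=O)ccc1Oc1ncnc(OC2CCN(C(=O)C(F)(F)F)CC2)c1F` gives 76%.

The three compounds share one core and differ only in the group on the carbonyl carbon attached to the piperidine nitrogen. Compound 3, carrying a trifluoromethyl there, stands level with compound 2 at the digits shown, the two together at the lower end of the three numbers, while compound 1 sits a little higher; all three lie within the usual scatter of one another. The recorded steps confirm this: a number 3 percentage points lower from compound 1 to compound 3 (within the scatter) and no change at the digits printed from compound 2 to compound 3 (within the scatter), each within the scatter, and likewise a number 3 percentage points lower from compound 1 to compound 2 (within the scatter).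

Compound 4 `CCC(F)(F)C(=O)N1CCC(Oc2ncnc(Oc3ccc(S(C)(=O)=O)nc3C)c2F)CC1` is the next member of this set and differs from compound 3 by ethyl in place of fluoro on a saturated chain carbon bound to a carbonyl carbon and two fluorine atoms; the same difference, cut one bond further out, reads trifluoromethyl to 1,1-difluoropropyl. Every earlier change at this carbonyl substituent, whether to an alkoxy, a thioether or a trifluoromethyl group, moved the maximal response by no more than the scatter. Among the measured compounds shown here, no measured step shows a change of this kind, so the expectation rests on the general stability of this position.

Compound 4 is therefore expected to give 76% in this assay, with a range of 66% to 86%, meaning an expected step of no change at the digits printed from compound 3 to compound 4 (within the scatter), not beyond the scatter.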

Compound 4, largest response reached (reported as efficacy), in percent of the reference or control that the assay uses: 90%
Compound 4: the middle estimate sits 14 percentage points below what was measured, and the stated range ends below it.
By their numbers in this assay, from the lowest: compounds 2, 3 and 1 (each within the scatter of the next); then compound 4.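

In this assay, among the compounds shown here, the group on the carbonyl carbon is not indifferent after all: ethyl in place of fluoro on a saturated chain carbon bound to a carbonyl carbon and two fluorine atoms gives a number 14 percentage points higher from compound 3 to compound 4 (beyond the scatter), the first step in this set to clear the scatter. The 1,1-difluoropropyl group also stands apart from the other two groups on that carbonyl carbon, with a number 14 percentage points higher from compound 2 to compound 4 (beyond the scatter) and a number 11 percentage points higher from compound 1 to compound 4 (beyond the scatter), so the near-identical readings of the three earlier compounds did not mark the full range of this position. Nothing available bears on why the maximal response rises with this change.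

The compounds shown leave open whether the higher response follows the length of the chain, as a 1,1-difluoroethyl or 1,1-difluorobutyl group on the carbonyl carbon would show, or requires the two fluorine atoms, as a plain propyl group there would show. They also leave open how a branched or cyclic carbon group, such as isopropyl or cyclopropyl, would behave at this carbonyl carbon.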